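Swapping Chloro for Bromo on the Triazole

This account rests on a few compounds, and the source may have more. Where it says the series, first, only, none or still open, it means among the compounds named here.

Measured so far:
Compound 1 `O=C1O[C@@H](Cn2cc(Cl)nn2)CN1c1ccc(C2=CCS(=O)(=O)CC2)c(F)c1` gives 3000 nM in an assay for binding affinity to Amine oxidase [flavin-containing] A (Homo sapiens); a higher number here means a weaker inhibitor, a lower number a stronger inhibitor.
Compound 2 `CCc1cn(C[C@H]2CN(c3ccc(C4=CCS(=O)(=O)CC4)c(F)c3)C(=O)O2)nn1` gives only the limit > 200000 nM.
Compound 3 `C#Cc1cn(C[C@H]2CN(c3ccc(C4=CCS(=O)(=O)CC4)c(F)c3)C(=O)O2)nn1` gives only the limit > 200000 nM.

Within the data shown here, compound 1 holds the only real number among the three; the other two results are limits. Compound 4 `O=C1O[C@@H](Cn2cc(Br)nn2)CN1c1ccc(C2=CCS(=O)(=O)CC2)c(F)c1` differs from compound 1 by bromo in place of chloro on an aromatic carbon. The measured steps at that carbon are an at least 66-fold higher number from compound 1 to compound 2 (1.82 log units; beyond the scatter) and an at least 66-fold higher number from compound 1 to compound 3 (1.82 log units; beyond the scatter), both ending at the limit of > 200000 nM in this assay, at which 2 of the 3 values shown sit. Those two changes put in carbon-based groups, whereas bromo keeps a halogen, so a smaller shift is expected, possibly within the scatter of this assay. Compound 4 is therefore estimated at 4000 nM, with a range of 1000 nM to 30000 nM. The step this estimate implies is a 1.3-fold higher number from compound 1 to compound 4 (0.12 log units; within the scatter).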

Compound 4, inhibition constant: 16000 nM
Estimate against measurement, compound 4: 4.0-fold (0.60 log units) below; the measured number falls inside the stated range.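

In this assay, even exchanging one halogen for another on this carbon makes a difference beyond the scatter (a 5.3-fold higher number from compound 1 to compound 4 (0.73 log units; beyond the scatter)). Bromo still gives a far lower number than ethyl (an at least 12-fold lower number from compound 2 to compound 4 (1.09 log units; beyond the scatter)) or ethynyl (an at least 12-fold lower number from compound 3 to compound 4 (1.09 log units; beyond the scatter)), so the halogens stay apart from those two carbon-based groups in the compounds shown. Both of those steps start from limits, not from measured numbers: the limit of > 200000 nM in this assay, at which 2 of the 4 values shown sit.

Going by these compounds, whether fluoro or iodo on this carbon would extend the change seen from chloro to bromo stays open. So does where a methyl or an amine at this position would fall.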